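The compounds below may be only part of what the source reports. "The series", "measured", "known", "first", "only" and "open" are said of these compounds alone.

Measured compounds:
compound 1 `CC(=O)O[C@@H]1C=CC(=O)O[C@@H]1[C@@H](COC(=O)c1ccc([N+](=O)[O-])cc1)OC(C)=O` gives 1110 nM
compound 2 `COc1ccc(/C=C/C(=O)OC[C@@H](OCc2ccccc2)[C@H]2OC(=O)C=C[C@H]2OCc2ccccc2)cc1` gives 1570 nM

Both values come from a functional assay on HL-60 cells (Homo sapiens) for antiproliferative activity, read by MTT assay, with a stated time of 6 days; on this read-out higher numbers stand for weaker inhibition and lower numbers for stronger inhibition. Compound 2 and compound 1 sit within the scatter of each other, so nothing separates the two on the numbers shown; no step between measured compounds can be read from this pair, as they differ in more than one place.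

Compound 3 `O=C1C=C[C@@H](OCc2ccccc2)[C@@H]([C@@H](COC(=O)/C=C/c2ccc([N+](=O)[O-])cc2)OCc2ccccc2)O1` is the next member. It differs from compound 2 by nitro in place of methoxy on an aromatic carbon. Among the measured compounds shown here, no measured pair shows this change on its own, so there is no precedent for its size or direction. Compound 1 already carries a nitro group on an aromatic ring and lies within the scatter of compound 2, which is weak support for expecting little movement. The step from compound 2 to compound 3 is therefore expected to be small, a 1.3-fold lower number from compound 2 to compound 3 (0.12 log units; within the scatter), in no clear direction beyond the scatter. Compound 3 is estimated at 1200 nM, with a range from 400 nM to 3600 nM.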

Compound 3, half-maximal inhibitory concentration: 2530 nM
Beside the measured number, compound 3's estimate is 2.1-fold (0.32 log units) below it; low and high end bracket the measured number.
By their numbers in this assay, from the lowest: compounds 1, 2 and 3 (each within the scatter of the next, the first and the last beyond it).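

In this assay, nitro in place of methoxy on an aromatic carbon, para to a large group, gives a 1.6-fold higher number from compound 2 to compound 3 (0.21 log units; within the scatter). Among the compounds shown here, this is the first matched reading of the change, and it shows that exchanging 4-methoxyphenyl for 4-nitrophenyl on the 2-(aryl)ethenyl group does not separate compound 2 and compound 3 on the numbers available. No measured evidence bears on this result.

As far as these compounds go, whether an amine, a carboxylic acid or a plain unsubstituted phenyl at the same position would move the number beyond the scatter remains open. For the compounds shown here, compound 1 differs from both compound 2 and compound 3 in more than one place, so no step to it can be read, and the contribution of the benzyl ethers and the ester chain stays unresolved.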